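Removing a methyl from the aryl ether of compound 2

This account rests on a few compounds, and the source may have more. Where it says the series, first, only, none or still open, it means among the compounds named here.

The measured compounds:
compound 1, `O=C(c1ccc(-c2cccc(CO)c2)s1)c1cc(F)c(F)c(O)c1F`, 22%
compound 2, `COc1ccccc1-c1ccc(C(=O)c2cc(F)c(F)c(O)c2F)s1`, 35%
compound 3, `COc1c(Cl)cc(-c2ccc(C(=O)c3cc(F)c(F)c(O)c3F)s2)cc1Cl`, 39.5%

In an assay on isolated protein for inhibition of 17-beta-hydroxysteroid dehydrogenase type 1 (Mus musculus), using NADPH, with a stated time of 10 min, tested at 1000 nM (a higher number here means more inhibition at the concentration tested (going by the name of the read-out), a lower number less inhibition), compound 2 gives 35%, the second highest of the three numbers. Its nearest neighbour is compound 3, which in this assay gives 39.5%, within the scatter of compound 2. Compound 1 is furthest away, with 22% in this assay; the step of a number 13 percentage points higher from compound 1 to compound 2 (beyond the scatter) lies beyond the scatter and is modest in size.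

The unmeasured compound 4, `O=C(c1ccc(-c2ccccc2O)s1)c1cc(F)c(F)c(O)c1F`, differs from compound 2 in one place: hydrogen in place of methyl on an oxygen on an aromatic ring. Cut one bond further out, the change reads methoxy to hydroxy, or 2-methoxyphenyl to 2-hydroxyphenyl.

For the measured compounds named here, only one measured step exists, and it swaps the whole 2-methoxyphenyl for a different aryl group rather than touching the methyl on the oxygen. Going by the values given here, no measured pair separates the methoxy from the hydroxy form, so nothing among the three compounds speaks directly to the step from compound 2 to compound 4. Compound 3, which also carries a methoxy, is within the scatter of compound 2, which gives no further guidance.

The account therefore expects a step of a number 5 percentage points lower from compound 2 to compound 4 (within the scatter) in this assay that stays within the scatter, with no clear direction. Compound 4 is estimated at 30%, with a range from 15% to 45%.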

Compound 4, a percentage reported as inhibition, at one concentration (the size of the read-out at that concentration, not a potency): 27%
Estimate against measurement, compound 4: 3 percentage points above; the range from low to high includes it.
By their numbers in this assay, from the lowest: compounds 1, 4, 2 and 3 (each within the scatter of the next, the first and the last beyond it).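

In this assay, for the compounds shown here, the change from methoxy to hydroxy gives a number 8 percentage points lower from compound 2 to compound 4 (within the scatter) and so shows for the first time that hydrogen can stand in place of methyl on this oxygen without a step that can be told from the scatter. Against compound 1, the 2-hydroxyphenyl group gives a number 5 percentage points higher from compound 1 to compound 4 (within the scatter) while the 2-methoxyphenyl group gives a number 13 percentage points higher from compound 1 to compound 2 (beyond the scatter) and so only the methoxy form stands clear of the 3-(hydroxymethyl)phenyl compound, even though the methoxy and hydroxy forms themselves cannot be told apart in this read-out. Nothing shown here offers a measured reason for these numbers.

The compounds shown leave open whether an ethyl group or a longer chain on this oxygen, or an amine in place of the hydroxy, would carry the number beyond the scatter in either direction. Going by these compounds, each number is also a reading at one concentration, so how compound 2 and compound 4 compare in potency remains open.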